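Aryl group replacement on the ring nitrogen: compound 4

The source may report more compounds than this note shows. Statements on the series, on what has been measured and on what is new or still open speak of the compounds shown alone.

Measured compounds:
compound 1 `CC1(C)[C@H]2CC[C@]1(C)N(Cc1cn(-c3ccccc3Br)nn1)C(=O)C2` — 130 nM
compound 2 `CC1(C)[C@H]2CC[C@]1(C)N(Cc1cn(-c3cccc(C#N)c3)nn1)C(=O)C2` — 440 nM
compound 3 `CC1(C)[C@H]2CC[C@]1(C)N(Cc1cn(-c3ccccc3F)nn1)C(=O)C2` — 240 nM

All three numbers come from a functional assay on A549 cells (Homo sapiens) for inhibition, read by MTT assay, with a stated time of 24 h; a lower number here means a stronger inhibitor, a higher number a weaker inhibitor. Compound 1 gives the lowest of the three numbers in this assay. Its nearest neighbour is compound 3, at a 1.8-fold higher number from compound 1 to compound 3 (0.27 log units; within the scatter) — within the scatter, so no order between these two is claimed. Its furthest is compound 2, at a 3.4-fold higher number from compound 1 to compound 2 (0.53 log units; beyond the scatter), which is beyond the scatter.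

Compound 4 `CC1(C)[C@H]2CC[C@]1(C)N(Cc1cn(-c3cccc(O)c3)nn1)C(=O)C2` differs from compound 1 as follows: 3-hydroxyphenyl in place of 2-bromophenyl on an aromatic nitrogen

Among the compounds with values here, only one measured step bears on this change, the one in which a 3-cyanophenyl replaced the 2-bromophenyl, a 3.4-fold higher number from compound 1 to compound 2 (0.53 log units; beyond the scatter), a modest loss. The step of a 1.8-fold lower number from compound 2 to compound 3 (0.26 log units; within the scatter) is within the scatter and adds no direction. Within the data shown here, no measured compound carries a hydrogen-bond donor on this aryl group, so the expectation rests on that single step alone. Compound 4 is therefore expected to give a modestly higher number than compound 1, a 2.3-fold higher number from compound 1 to compound 4 (0.36 log units; beyond the scatter), with an estimate of 300 nM and a range of 120 nM to 800 nM.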

Compound 4, half-maximal inhibitory concentration: 180 nM
Beside the measured number, compound 4's estimate is 1.7-fold (0.22 log units) above it; measured number inside the range.
By their numbers in this assay, from the lowest: compounds 1, 4, 3 and 2 (each within the scatter of the next, the first and the last beyond it).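

In this assay, 3-hydroxyphenyl, the only aryl group shown here with a hydrogen-bond donor, cannot be separated from the halogen-bearing groups: a 1.4-fold higher number from compound 1 to compound 4 (0.14 log units; within the scatter) and a 1.3-fold lower number from compound 3 to compound 4 (0.12 log units; within the scatter), so no order is claimed among these compounds. Hydroxy in place of cyano on the aromatic carbon gives a 2.4-fold lower number from compound 2 to compound 4 (0.39 log units; beyond the scatter), so the two 3-substituted phenyl groups shown do not behave alike. No available evidence accounts for these differences.

Still open, on these data alone, is whether an amine or a carboxylic acid on the same carbon of the phenyl ring would stay with compound 4 or give a number closer to that of compound 2. Also open is how the unsubstituted phenyl group and 2-hydroxyphenyl would compare with the aryl groups shown.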